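Swapping an open chain for a ring on compound 2

The source may report more compounds than this note shows. Statements on the series, on what has been measured and on what is new or still open speak of the compounds shown alone.

Compound 1 `O=C1c2c[n+]([O-])c3ccccc3c2C(=O)c2c1c1ccccc1n2Cc1cn(C[C@H](O)CO)nn1`: 1130 nM
Compound 2 `O=C1c2c[n+]([O-])c3ccccc3c2C(=O)c2c1c1ccccc1n2Cc1cn(CC(O)CO)nn1`: 1070 nM
Compound 3 `CCCN1CCN(CCCCn2c3c(c4ccccc42)C(=O)c2c[n+]([O-])c4ccccc4c2C3=O)CC1`: 6830 nM

In a toxicity assay on L02 cells (Homo sapiens) for cytotoxicity, read by MTT assay, with a stated time of 72 h (a lower number here means a stronger inhibitor, a higher number a weaker inhibitor), compound 2 has the lowest of the three numbers, but compound 1 lies within the scatter of it, so the two cannot be ranked. Compound 4 `O=C1c2c[n+]([O-])c3ccccc3c2C(=O)c2c1c1ccccc1n2Cc1cn([C@H]2C[C@H](O)[C@@H](CO)O2)nn1` differs from compound 2 at one place: 4-hydroxy-5-(hydroxymethyl)oxolan-2-yl in place of 2,3-dihydroxypropyl on an aromatic nitrogen.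

Two measured steps offer some guidance. The first is a 1.1-fold lower number from compound 1 to compound 2 (0.02 log units; within the scatter), and it involves only (the fact that one of compounds 1 and 2 is drawn with a defined configuration and the other without, at the place where they differ). The second is larger, a 6.4-fold higher number from compound 2 to compound 3 (0.81 log units; beyond the scatter), but it replaces the whole 1-(2,3-dihydroxypropyl)-1H-1,2,3-triazol-4-yl group, whereas compound 4 keeps the five-membered aromatic ring with 3 nitrogen. Neither step tests a ring on that nitrogen, so the guidance is indirect. Compound 4 changes less than compound 3 does, so in this assay no step beyond the scatter is expected, though a modest move in either direction remains possible.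

The expected change is a 1.2-fold higher number from compound 2 to compound 4 (0.08 log units; within the scatter). For compound 4 the estimated value is 1300 nM, within an expected range of 450 nM to 4000 nM.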

Compound 4, half-maximal inhibitory concentration: 280 nM
Beside the measured number, compound 4's estimate is 4.6-fold (0.67 log units) above it; measured number below the stated range.
By their numbers in this assay, from the lowest: compound 4; then compounds 2 and 1 (each within the scatter of the next); then compound 3.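

In this assay, the group on the aromatic nitrogen of the five-membered aromatic ring with 3 nitrogen turns out to matter: 4-hydroxy-5-(hydroxymethyl)oxolan-2-yl in place of 2,3-dihydroxypropyl gives a 3.8-fold lower number from compound 2 to compound 4 (0.58 log units; beyond the scatter), and the same exchange gives a 4.0-fold lower number from compound 1 to compound 4 (0.61 log units; beyond the scatter). The earlier compounds shown here could not show this, since compounds 1 and 2 differ only in how one stereocentre of the open chain is drawn, and compound 3 replaces the five-membered aromatic ring along with its substituent. Nothing shown here explains why the number falls with this exchange.

The exchange alters several things at once, adding one five-membered non-aromatic ring with 1 hetero atom, more heavy atoms, a further hydrogen-bond acceptor and 3 defined stereocentres, and the compounds shown do not separate these contributions. From the compounds shown here alone, it remains open how the number would respond to a plain oxolan-2-yl group with no hydroxy groups, to an amine in place of the hydroxymethyl group, or to the opposite configuration at those stereocentres.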